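The source may report more compounds than this note shows. Statements on the series, on what has been measured and on what is new or still open speak of the compounds shown alone.

Working notes on the series. Compound 1 `Nc1scc(CN2CCN(c3cccc(Cl)c3Cl)CC2)c1C(=O)c1ccc(Cl)cc1` and compound 2 `Nc1scc(CN2CCN(c3ccncc3)CC2)c1C(=O)c1ccc(Cl)cc1` share one core and differ only in the aryl group on the amine nitrogen of the six-membered ring. In a functional assay on CHO cells with adenosine receptor A1 (Homo sapiens) as the target, read by cAMP accumulation and immunoassay, with a stated time of 6 min, tested at 0.1 uM (a higher number here means a weaker effect of the compound at the concentration tested, a lower number a stronger effect), compound 1 gives 3.2%, and compound 2 gives 1.4%. On these numbers compound 1 and compound 2 cannot be told apart: the step of a number 1.8 percentage points lower from compound 1 to compound 2 (within the scatter) is within the scatter, so neither is read as stronger or weaker at the concentration tested. Compound 3 `Nc1scc(CN2CCN(c3cc(F)cc(F)c3)CC2)c1C(=O)c1ccc(Cl)cc1` has not yet been measured. It differs from compound 1 in one place: 3,5-difluorophenyl in place of 2,3-dichlorophenyl on an amine nitrogen in a ring. Going by the values given here, the only measured step that bears on this change is the one at the same ring nitrogen, a number 1.8 percentage points lower from compound 1 to compound 2 (within the scatter), where exchanging 2,3-dichlorophenyl for pyridin-4-yl moved the number by less than the scatter. The change to compound 3 keeps a carbon-only aromatic ring and alters only the halogens, so nothing in the data points to a step beyond the scatter in this assay. The step of a number 0.2 percentage points lower from compound 1 to compound 3 (within the scatter) is accordingly expected to be small. For compound 3 the estimate in this assay is 3%, within -6% to 12%.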

Compound 3, a percentage reported as activity, at one concentration (the size of the read-out at that concentration, not a potency): -5%
For compound 3 the middle estimate is 8 percentage points above the measured one; low and high end bracket the measured number.
By their numbers in this assay, from the lowest: compounds 3, 2 and 1 (each within the scatter of the next).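

In this assay the same ring nitrogen now gives two further readings, a number 8.2 percentage points lower from compound 1 to compound 3 (within the scatter) and a number 6.4 percentage points lower from compound 2 to compound 3 (within the scatter) and so 3,5-difluorophenyl cannot be told apart from either 2,3-dichlorophenyl or pyridin-4-yl at the concentration tested. With all three compounds within the scatter of their neighbours, this position has not yet yielded a group that separates from the others in this read-out, and the exchange of 2,3-dichlorophenyl for 3,5-difluorophenyl, which alters both the halogen and where it stands, gives no separate reading for either alteration. No independent measurement is available to explain these readings.

Still open, going by these compounds, is whether a group of another kind on this ring nitrogen, such as cyclohexyl, acetyl or a methoxy-substituted phenyl, would give a step beyond the scatter. On these data alone, the readings come from a single concentration, so whether compound 1, compound 2 and compound 3 would show a stronger or weaker effect at any other concentration also remains open.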